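The source may hold more compounds than are shown below. What is called first, only, known or untested is meant among the compounds shown, and "the series" means these compounds.

Compound 1 `Cc1ccc(C2=NN(c3ccc(S(C)(=O)=O)cc3)C(=O)CC2)cc1`: > 100000 nM (a limit)
Compound 2 `Cc1cc(O)ccc1C1=NN(c2ccc(S(C)(=O)=O)cc2)C(=O)CC1`: 76900 nM

Among the measured compounds shown here, in a functional assay on OVCAR-4 cells (Homo sapiens) for inhibition, read by sulforhodamine B assay, with a stated time of 48 h (a higher number here means a weaker inhibitor of growth, a lower number a stronger inhibitor of growth), compound 2 gives 76900 nM, the only true number so far. Compound 1 gives > 100000 nM, which is a limit of the assay and not a number.

Compound 3 `CCc1ccc(C2=NN(c3ccc(S(C)(=O)=O)cc3)C(=O)CC2)cc1` has 4-ethylphenyl in place of 4-hydroxy-2-methylphenyl on a carbon with a double bond to nitrogen. The hydroxy group is gone, and the new group resembles the 4-methylphenyl of compound 1. For the measured compounds named here, the one measured step that bears on this is an at least 1.3-fold lower number from compound 1 to compound 2 (0.11 log units; that floor lies within the scatter). It is small, so undoing it should change little in this assay, and no clear shift in either direction is expected. The expected step is a 1.2-fold higher number from compound 2 to compound 3 (0.09 log units; within the scatter), which would stay within the scatter. The estimate for compound 3 is 95000 nM, with an expected range of 50000 nM to 180000 nM.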

Compound 3, concentration for 50% growth inhibition: 10 nM
Beside the measured number, compound 3's estimate is 9500-fold (3.98 log units) above it, and the stated range ends above it.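

In this assay, among the compounds shown here, this position proves far more sensitive than the earlier compounds suggested: 4-ethylphenyl in place of 4-hydroxy-2-methylphenyl gives a 7700-fold lower number from compound 2 to compound 3 (3.89 log units; beyond the scatter). The sharpest contrast comes from a very small edit, methyl in place of hydrogen on a saturated chain carbon bound to an aromatic carbon, which turns the 4-methylphenyl of compound 1 into the 4-ethylphenyl of compound 3 and gives an at least 10000-fold lower number from compound 1 to compound 3 (4.00 log units; beyond the scatter). Compound 1 stands at a limit of the assay, so that step is a floor and not an exact size: the limit of > 100000 nM in this assay, at which 1 of the 3 values shown sits.

The compounds shown leave open whether a longer chain such as propyl or butyl, or an ethoxy group, would keep this strength in place of ethyl. They also give no reason why so small a change has so large an effect.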